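This account rests on a few compounds, and the source may have more. Where it says the series, first, only, none or still open, it means among the compounds named here.

Compound 1 `COc1cccc(Cc2ccnn(CC(=O)Nc3ccc(Br)cc3)c2=O)c1`: 15900 nM
Compound 2 `COc1cccc(Cc2cc(C3CCCCC3)nn(CC(=O)Nc3ccc(Br)cc3)c2=O)c1`: 2500 nM

In a functional assay on cells (Neutrophil, Homo sapiens) for activation, read by luminescence, with a stated time of 60 min (a lower number here means that less compound is needed, a higher number that more compound is needed for the effect), compound 2 gives the lower of the two numbers; the step of a 6.4-fold lower number from compound 1 to compound 2 (0.80 log units; beyond the scatter) is modest but beyond the scatter. Compound 3 `COc1cccc(Cc2cc(-c3ccccc3)nn(CC(=O)Nc3ccc(Br)cc3)c2=O)c1` differs from compound 2 by phenyl in place of cyclohexyl on an aromatic carbon. Going by the values given here, no measured step exchanges one six-membered ring for another on the same aromatic carbon; the only related step, a 6.4-fold lower number from compound 1 to compound 2 (0.80 log units; beyond the scatter), shows that adding a six-membered ring there lowers the number, but whether an aromatic ring does as much is untested. Compound 3 is therefore expected to stay close to compound 2's level, with an estimated change of a 1.4-fold higher number from compound 2 to compound 3 (0.15 log units; within the scatter) and an estimated value of 3500 nM (range 900 nM to 14000 nM).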

Compound 3, half-maximal effective concentration: 600 nM
Compound 3: the middle estimate sits 5.8-fold (0.77 log units) above what was measured, outside the stated range (below it).
By their numbers in this assay, from the lowest: compound 3; then compound 2; then compound 1.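

In this assay, this position responds not only to whether a six-membered ring is present but to which one: with six heavy atoms in both groups, replacing cyclohexyl with phenyl gives a 4.2-fold lower number from compound 2 to compound 3 (0.62 log units; beyond the scatter). Replacing the hydrogen with phenyl gives a 27-fold lower number from compound 1 to compound 3 (1.42 log units; beyond the scatter), a large step, whereas the cyclohexyl step was modest. Nothing available bears on the reason for this difference. The compounds shown leave open how a pyridine ring or a methyl group would behave at this position, and whether a methoxy group on the phenyl would change the number.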